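Butoxy to allyloxy on the shared core: cytotoxicity notes

The source may report more compounds than this note shows. Statements on the series, on what has been measured and on what is new or still open speak of the compounds shown alone.

Measured in a functional assay on HepG2 cells (Homo sapiens) for cytotoxicity, read by MTT assay, with a stated time of 48 h; on this read-out higher numbers stand for weaker inhibition and lower numbers for stronger inhibition:
- compound 1 `CCCCOc1ccc2c(Cl)ccnc2c1` gives 2640 nM
- compound 2 `Clc1ccnc2cc(OCCCc3ccccc3)ccc12` gives 1780 nM
- compound 3 `Clc1ccnc2cc(OCCc3ccccc3)ccc12` gives 3310 nM

Compound 1 has the second highest of the three numbers in this assay; its nearest neighbour is compound 3, its furthest compound 2, and both gaps sit within the scatter.

Compound 4 `C=CCOc1ccc2c(Cl)ccnc2c1` differs from compound 1 in one place: vinyl in place of propyl on a saturated chain carbon bound to an oxygen on an aromatic ring.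

Going by the values given here, no measured step cuts the chain in this way. The steps that come closest alter the end of the same alkoxy chain: a 1.5-fold lower number from compound 1 to compound 2 (0.17 log units; within the scatter), a 1.3-fold higher number from compound 1 to compound 3 (0.10 log units; within the scatter) and a 1.9-fold higher number from compound 2 to compound 3 (0.27 log units; within the scatter). All three are within the scatter, so across the three compounds nothing at the chain end has moved the read-out of this assay beyond the scatter. Shortening the chain and introducing a double bond is a different change, but with only this to go on, no step beyond the scatter in either direction is expected from compound 1 to compound 4 in this assay.

Compound 4 is therefore estimated at 2600 nM, range 1200 nM to 5600 nM, an expected step of a 1.0-fold lower number from compound 1 to compound 4 (0.01 log units; within the scatter).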

Compound 4, half-maximal inhibitory concentration: 2770 nM
The estimate for compound 4 lay 1.1-fold (0.03 log units) below the measured number; the range from low to high includes it.
By their numbers in this assay, from the lowest: compounds 2, 1, 4 and 3 (each within the scatter of the next).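

The butoxy to allyloxy change gives a 1.0-fold higher number from compound 1 to compound 4 (0.02 log units; within the scatter) in this assay. Until now, the steps at this chain swapped one saturated chain end for another, with or without a phenyl. Compound 4 adds a different kind of change at the carbon bound to the oxygen on the aromatic ring: vinyl for propyl, with one heavy atom fewer and a double bond outside aromatic rings, and the step still lies within the scatter. No measurement here speaks to why this step stays so small.

From the compounds shown here alone, whether a chain ending in an amine or a carboxylic acid would step beyond the scatter in this assay remains open. Also open, going by these compounds, is what happens when the chlorine carried by the shared core of all four compounds gives way to a methoxy group.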